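Trifluoromethyl to fluoro on the aryl ether

The source may hold more compounds than are shown below. What is called first, only, known or untested is meant among the compounds shown, and "the series" means these compounds.

Measured so far:
compound 1, `O=c1cc(-n2cc(COc3cccnc3)nn2)c2cc(Br)ccc2o1`: 24800 nM
compound 2, `O=c1cc(-n2cc(COc3ccc(C(F)(F)F)cc3)nn2)c2cc(Br)ccc2o1`: 1620 nM

Both numbers come from a functional assay on A549 cells (Homo sapiens) for antiproliferative activity, read by MTT assay, with a stated time of 48 h; on this read-out higher numbers stand for weaker inhibition and lower numbers for stronger inhibition. Of the two, compound 2 stands at the lower value, and the gap up to compound 1 lies well beyond the scatter, so compound 2 is the stronger of the pair as measured.

The next member is compound 3, `O=c1cc(-n2cc(COc3ccc(F)cc3)nn2)c2cc(Br)ccc2o1`. Relative to compound 2 the change is fluoro in place of trifluoromethyl on an aromatic carbon; the rest of the structure is unchanged. Going by the values given here, no measured pair shows this particular exchange, so there is no recorded step to lean on. The expectation is that compound 3 gives a somewhat higher number than compound 2 in this assay, a step of moderate size that may or may not clear the scatter, estimated as a 3.1-fold higher number from compound 2 to compound 3 (0.49 log units; beyond the scatter). On that basis the value of compound 3 in this assay is estimated at 5000 nM, with a range from 1500 nM to 16000 nM.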

Compound 3, half-maximal inhibitory concentration: 850 nM
Beside the measured number, compound 3's estimate is 5.9-fold (0.77 log units) above it, outside the stated range (below it).
By their numbers in this assay, from the lowest: compounds 3 and 2 (each within the scatter of the next); then compound 1.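

In this assay, fluoro in place of trifluoromethyl on this aromatic carbon, para to a large group, gives a 1.9-fold lower number from compound 2 to compound 3 (0.28 log units; within the scatter), so the read-out does not separate these two groups at this position. The large change lies in the other exchange, 4-fluorophenyl in place of pyridin-3-yl, which gives a 29-fold lower number from compound 1 to compound 3 (1.47 log units; beyond the scatter), so among these three compounds the identity of the aryl ring on the ether oxygen counts for far more than the choice between the two substituents. Nothing on hand gives a reason for either step.

Still open, going by these compounds, is whether an amine or a carboxylic acid on this same aromatic carbon would read like compound 2 and compound 3 or fall toward compound 1. Also open, on these data alone, is how a chloro group or a methoxy group would read there.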